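Cytotoxicity notes: replacing the hydroxybutyl chain

The source may hold more compounds than are shown below. What is called first, only, known or untested is meant among the compounds shown, and "the series" means these compounds.

Measured so far in an ADME assay on HEp-2 cells (Homo sapiens) for cytotoxicity, read by CCK-8 assay, with a stated time of 6 days; on this read-out higher numbers stand for lower toxicity in this test and lower numbers for higher toxicity in this test:
compound 1 `Cc1ccn2c(CCCCO)c(Cn3c(=O)n(C4CC4)c4ccncc43)nc2c1` — > 100000 nM, a limit of the assay
compound 2 `O=c1n(Cc2nc3ccccn3c2CCCCO)c2cnccc2n1C1CC1` — > 100000 nM, a limit of the assay
compound 3 `O=c1n(Cc2nc3cc(Cl)ccn3c2CCCCO)c2cnccc2n1C1CC1` — > 100000 nM, a limit of the assay

All three compounds of the shared core come back at the same assay limit in this assay. The steps among them, a step that the two limits leave unreadable from compound 1 to compound 2, a step that the two limits leave unreadable from compound 1 to compound 3 and a step that the two limits leave unreadable from compound 2 to compound 3, cannot be sized, since (the limit of > 100000 nM in this assay, at which 3 of the 3 values shown sit). Compound 3 therefore stands at that limit with the other two, and no number lies beneath it.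

Compound 4 `O=C(O)/C=C/c1c(Cn2c(=O)n(C3CC3)c3ccncc32)nc2cc(Cl)ccn12` differs from compound 3 by 2-carboxyethenyl in place of 4-hydroxybutyl on an aromatic carbon. For the measured compounds named here, none of the measured steps touches this chain; each exchanges a substituent on an aromatic carbon and leaves the 4-hydroxybutyl group untouched, and each is unreadable, so they offer no direction for the new step. With nothing pointing either way, compound 4 is expected to stay at the limit as well, the estimated step being a number no higher from compound 3 to compound 4 (the limit leaves the size open). The value for compound 4 is accordingly estimated at 100000 nM, within a range from 50000 nM to 200000 nM.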

Compound 4, half-maximal cytotoxic concentration: > 100000 nM
Compound 4 ended at the assay's limit; the forecaster's own chance of this, stated with the estimate: 85%; the middle value sits exactly at the limit.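

For the compounds shown here, compound 3 and compound 4 both sit at a limit of the assay, so no step between them can be read: the limit of > 100000 nM in this assay, at which 4 of the 4 values shown sit. The compounds shown leave open whether 2-carboxyethenyl in place of 4-hydroxybutyl, or any other exchange in the series, changes the cytotoxic concentration in this assay at all.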